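Series notes: the step from compound 3 to compound 4

This account rests on a few compounds, and the source may have more. Where it says the series, first, only, none or still open, it means among the compounds named here.

Three compounds on a shared core have numbers in an ADME assay on RAW264.7 cells (Mus musculus) for cytotoxicity, read by trypan blue exclusion, with a stated time of 48 h; a lower number here means a stronger inhibitor of growth, a higher number a weaker inhibitor of growth. Compound 1 (`Cc1cc(/C=N\OCc2ccccc2)c(C)n1-c1ccc(Cl)cc1`) gives 128 ug/mL. Compound 2 (`Cc1cc(CNCc2ccccc2)c(C)n1-c1ccc(Cl)cc1`) gives 5.5 ug/mL. Compound 3 (`Cc1cc(CN2CCN(C3C[C@@H]4CC[C@H]3C4)CC2)c(C)n1-c1ccc(Cl)cc1`) gives 5.6 ug/mL. This places compound 3 within the scatter of compound 2, while its gap to compound 1 is large and beyond the scatter.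

Compound 4 (`Cc1cc(CN2CCN(c3ccccc3)CC2)c(C)n1-c1ccc(Cl)cc1`) has no number yet. It differs from compound 3 by a group of 6 heavy atoms (6 carbon; one six-membered aromatic ring of carbon only) in place of a group of 7 heavy atoms (7 carbon; 2 five-membered non-aromatic rings of carbon only), on an amine nitrogen in a ring: a phenyl in place of a group with 2 five-membered non-aromatic rings of carbon only, on an amine nitrogen in a ring. Going by the values given here, no measured pair differs in one place only, so there is no direct precedent for this change, and any forecast is weakly anchored. The expectation rests mainly on compound 3 at 5.6 ug/mL, since compound 4 shares everything with it except this group. Compound 2 at 5.5 ug/mL also shows that a different group on the core can leave the number within the scatter of compound 3.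

In this assay the estimated step is a 1.4-fold higher number from compound 3 to compound 4 (0.15 log units; within the scatter), an expected small rise within the scatter. For compound 4 the estimated value is 8 ug/mL, with an expected range of 3 ug/mL to 30 ug/mL.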

Compound 4, concentration for 50% growth inhibition: 33 ug/mL
Beside the measured number, compound 4's estimate is 4.1-fold (0.62 log units) below it; measured number above the stated range.
By their numbers in this assay, from the lowest: compounds 2 and 3 (each within the scatter of the next); then compound 4; then compound 1.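

Going by these compounds alone, the pair of compound 3 and compound 4 is the first that differs in one place only, and in this assay it gives a 5.9-fold higher number from compound 3 to compound 4 (0.77 log units; beyond the scatter). The number therefore responds to the group on the amine nitrogen in the ring, with phenyl giving a weaker inhibitor of growth here than the group with 2 five-membered non-aromatic rings of carbon only, although both groups count 0 hydrogen-bond donors, 0 hydrogen-bond acceptors and no net charge. No measurement bears on the reason for this step.

This single pair changes the ring type, the heavy-atom count and the 2 defined stereocentres together, so it leaves open which of these differences goes with the higher number. A cyclohexyl on the same amine nitrogen would separate the aromatic ring from the size of the group, while a pyridyl or a benzyl would show whether the number stays near that of compound 4 (33 ug/mL) when the ring is altered or set further from the nitrogen.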